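A few compounds are considered here, and "the series" means these few. Any claim that something is new, unique, unknown or untested is made for them only; others in the source may bear on it.

Of the compounds shown here, three have been measured in a functional assay on CHO cells for agonist activity at Glucose-dependent insulinotropic receptor (Homo sapiens), read by a luciferase reporter and cAMP accumulation, with a stated time of 2 h; on this read-out lower numbers stand for an effect already at smaller amounts and higher numbers for an effect only at larger amounts of compound. Compound 1 `CC(C)(C)OC(=O)N1CCC(CCOC(=O)N2CCc3c2ccc(S(C)(=O)=O)c3F)CC1` gives 25 nM, compound 2 `Cc1c(S(C)(=O)=O)ccc2c1CCN2C(=O)OCCC1CCN(C(=O)OC(C)(C)C)CC1` gives 770 nM, and compound 3 `CC(C)OC(=O)N1CCC(Oc2cc(N3CCc4cc(S(C)(=O)=O)ccc43)ncn2)CC1` gives 17 nM. Compound 3 and compound 1 sit within the usual scatter of each other; both stand far from compound 2.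

Going by the values given here, only one single-point step is available: a 31-fold higher number from compound 1 to compound 2 (1.49 log units; beyond the scatter). That step swaps a substituent on an aromatic ring of the shared core and says nothing about the group carried by the ring nitrogen of the six-membered saturated ring. Compound 4 `CCc1cnc(N2CCC(Oc3cc(N4CCc5cc(S(C)(=O)=O)ccc54)ncn3)CC2)nc1` differs from compound 3 exactly there: 5-ethylpyrimidin-2-yl in place of isopropoxycarbonyl on an amine nitrogen in a ring. Among the compounds with values here, no measured pair exchanges a carbamate for an aromatic heterocycle at that nitrogen, so the direction of the step cannot be read from the data.

With no guidance either way, the number for compound 4 is expected to stay near that of compound 3, and the estimated step of a 1.1-fold lower number from compound 3 to compound 4 (0.05 log units; within the scatter) is taken to lie within the scatter. The estimate for compound 4 in this assay is 15 nM, with a range from 4 nM to 60 nM.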

Compound 4, half-maximal effective concentration in the Glucose-dependent insulinotropic receptor assay: 11 nM
Compound 4: middle estimate off by 1.4-fold (0.13 log units), on the high side; measured number inside the range.
By their numbers in the Glucose-dependent insulinotropic receptor assay, from the lowest: compounds 4, 3 and 1 (each within the scatter of the next, the first and the last beyond it); then compound 2.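

In the Glucose-dependent insulinotropic receptor assay the exchange gives a 1.5-fold lower number from compound 3 to compound 4 (0.19 log units; within the scatter), so compound 3 and compound 4 cannot be told apart on this read-out. Compounds 1, 2 and 3 all carry a carbamate on the amine nitrogen in the six-membered non-aromatic ring, and compound 4 now shows that a carbamate is not needed there: 5-ethylpyrimidin-2-yl, an aromatic ring with no carbonyl, serves as well in this pair. In a physicochemical assay for lipophilicity, read by HPLC, measured as octanol-water partition, at pH 7.4 (a lower number here means a more polar compound, a higher number a more lipophilic compound), compound 3 gives 3.1 and compound 4 gives 3.8 on this read-out. The exchange does have a measurable cost, since in the physicochemical assay compound 4 is the more lipophilic of the two: the measured distribution coefficient of compound 3, 3.1, and of compound 4, 3.8, a number 0.70 log units higher (beyond the scatter)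

As far as these compounds go, this rests on a single pair, so it remains open whether the same exchange would hold on the core of compound 1, and whether the ethyl group on the pyrimidine matters at all. Replacing that ethyl with a hydroxymethyl or a carboxylic acid, or placing a simple amide on the ring nitrogen, would show whether the numbers in the Glucose-dependent insulinotropic receptor assay and the physicochemical assay move together or apart at this position.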